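From Chlorobenzyl to Naphthylmethyl: An Expected Cell Result

The compounds below may be only part of what the source reports. "The series", "measured", "known", "first", "only" and "open" are said of these compounds alone.

Compound 1 `C/C(C#Cc1ccccc1)=N\N/C(N)=N/S(=O)(=O)c1cc(C)c(Cl)cc1SCc1cccc(C)c1`: 105000 nM
Compound 2 `C/C(C#Cc1ccccc1)=N\N/C(N)=N/S(=O)(=O)c1cc(C)c(Cl)cc1SCc1cccc(Cl)c1`: 21000 nM

In a functional assay on HeLa cells (Homo sapiens) for antiproliferative activity, read by MTT assay, with a stated time of 72 h (a higher number here means a weaker inhibitor, a lower number a stronger inhibitor), compound 2 gives 21000 nM, the lowest of the two numbers shown, and compound 1 gives 105000 nM. Among the measured compounds shown here, the single measured step, a 5.0-fold lower number from compound 1 to compound 2 (0.70 log units; beyond the scatter), swaps chloro for methyl on the aromatic ring attached through the sulfanyl chain, so that ring clearly matters. Compound 3 `C/C(C#Cc1ccccc1)=N\N/C(N)=N/S(=O)(=O)c1cc(C)c(Cl)cc1SCc1cccc2ccccc12` changes the same region more deeply: naphthalen-1-yl in place of 3-chlorophenyl on a saturated chain carbon bound to a sulfur. For the measured compounds named here, no measured pair shows a benzyl-to-naphthylmethyl swap, so the measured step gives only a hint that this part tolerates change and is not the whole answer. With the chlorine removed and two fused rings entering, a modest shift in either direction is possible; the estimate is a slight weakening, a 1.4-fold higher number from compound 2 to compound 3 (0.15 log units; within the scatter). Compound 3 is therefore expected to give about 30000 nM, within a range of 7000 nM to 120000 nM.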

Compound 3, half-maximal inhibitory concentration: 125000 nM
The estimate for compound 3 lay 4.2-fold (0.62 log units) below the measured number; measured number above the stated range.
By their numbers in this assay, from the lowest: compound 2; then compounds 1 and 3 (each within the scatter of the next).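

In this assay, naphthalen-1-yl in place of 3-chlorophenyl on a saturated chain carbon bound to a sulfur gives a 6.0-fold higher number from compound 2 to compound 3 (0.77 log units; beyond the scatter) and so shows that this position does not accept any larger aromatic group equally well. Naphthalen-1-yl in place of 3-methylphenyl at the same place gives a 1.2-fold higher number from compound 1 to compound 3 (0.08 log units; within the scatter) and leaves compound 1 and compound 3 within the scatter of each other, so among these three only compound 2, with its 3-chlorophenyl group, stands apart. No measurement shown here accounts for this difference.

Still open, on these data alone, is whether a fluoro or bromo group in place of the chlorine would keep the number of compound 2. Also open, as far as these compounds go, is how an amine or a carboxylic acid on that ring, or a longer chain before it, would read out.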